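A few compounds are considered here, and "the series" means these few. Any claim that something is new, unique, unknown or untested is made for them only; others in the source may bear on it.

For the measured compounds named here, compound 1 `CCCCC/C=C/C=C/C=N/Nc1nc(N)c2ncn([C@@H]3O[C@H](CO)[C@@H](O)[C@H]3O)c2n1` holds the lower of the two numbers so far in an assay on CHO-K1 cells for displacement of a labelled ligand from adenosine receptor A1 (Homo sapiens), read by scintillation counting, with a stated time of 60 min; on this read-out higher numbers stand for weaker inhibition and lower numbers for stronger inhibition: compound 1 gives 2 nM, whereas compound 2 `Nc1nc(N/N=C/c2cccc(OCc3ccccc3)c2)nc2c1ncn2[C@@H]1O[C@H](CO)[C@@H](O)[C@H]1O` gives 13 nM, a gap beyond the usual scatter. Compound 3 `COc1ccc(/C=N/Nc2nc(N)c3ncn([C@@H]4O[C@H](CO)[C@@H](O)[C@H]4O)c3n2)cn1` differs from compound 1 by a group of 8 heavy atoms (6 carbon, 1 nitrogen, 1 oxygen; one six-membered aromatic ring with 1 hetero atom) in place of a group of 9 heavy atoms (9 carbon; no ring), on a carbon with a double bond to nitrogen. Going by the values given here, no measured pair shows this step, yet a weaker number is expected because compound 2 with an aromatic ring gives 13 nM. The expected step from compound 1 to compound 3 is a 7.5-fold higher number from compound 1 to compound 3 (0.88 log units; beyond the scatter). Compound 3 is therefore estimated at 15 nM, with a likely range of 4 nM to 60 nM.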

Compound 3, inhibition constant: 2.6 nM
Compound 3: the middle estimate sits 5.8-fold (0.76 log units) above what was measured; the measured number lies below the stated range.
By their numbers in this assay, from the lowest: compounds 1 and 3 (each within the scatter of the next); then compound 2.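

In this assay the change on a carbon with a double bond to nitrogen, from the ring-free chain to 6-methoxypyridin-3-yl, is a 1.3-fold higher number from compound 1 to compound 3 (0.11 log units; within the scatter) and so leaves the number unchanged within the scatter. At this place, then, a low number does not depend on the ring-free chain, since this aromatic ring serves as well. Nothing measured here says why the two groups read alike. From the compounds shown here alone, it remains open what the methoxy group and the ring nitrogen each contribute, and how a plain phenyl ring, an amine or a carboxylic acid would read at this place.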